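Replacing a piperidine with a spiro-fused ring on the shared core

The compounds below may be only part of what the source reports. "The series", "measured", "known", "first", "only" and "open" are said of these compounds alone.

Measured compounds:
compound 1 `O=C(Nc1cccc(S(=O)(=O)C2CCCC2)c1)c1cccnc1N1CCCCC1`: 6350 nM
compound 2 `COc1ccc(C(=O)Nc2cccc(S(=O)(=O)C3CCCC3)n2)c(N2CCC3(CC2)CC3)c1`: 2660 nM
compound 3 `CC(C)(CO)Nc1ccc(C(=O)Nc2cccc(S(=O)(=O)NC3CCCC3)n2)c(N2CCC3(CC2)CC3)c1`: 48 nM

In a functional assay on OVCAR-3 cells (Homo sapiens) for activation, with a stated time of 24 h (a higher number here means that more compound is needed for the effect, a lower number that less compound is needed), compound 1 gives the highest of the three numbers. Compound 2 stands nearest to it, with a lower number that lies beyond the usual scatter, and compound 3 stands furthest away, with a far lower number. Compound 2 and compound 3 differ from compound 1 in several places at once, so none of these gaps can be tied to a single change.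

Compound 4 `O=C(Nc1cccc(S(=O)(=O)C2CCCC2)c1)c1cccnc1N1CCC2(CC1)CC2` has not yet been measured. It differs from compound 1 in one place: a group of 8 heavy atoms (7 carbon, 1 nitrogen; one three-membered non-aromatic ring of carbon only, one six-membered non-aromatic ring with 1 hetero atom) in place of a group of 6 heavy atoms (5 carbon, 1 nitrogen; one six-membered non-aromatic ring with 1 hetero atom), on an aromatic carbon. The change sits on an aromatic carbon of a six-membered aromatic ring with 1 nitrogen. For the measured compounds named here, no measured pair shows this change alone. Both compound 2 and compound 3 carry the entering group and give lower numbers than compound 1, yet they carry other differences too, so the step is estimated with caution.

For compound 4 a small step toward a lower number is expected, a 1.8-fold lower number from compound 1 to compound 4 (0.26 log units; within the scatter), possibly within the scatter. The estimate for compound 4 is 3500 nM, with a range from 1200 nM to 10000 nM.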

Compound 4, half-maximal effective concentration: 1870 nM
The estimate for compound 4 lay 1.9-fold (0.27 log units) above the measured number; the measured number falls inside the stated range.
By their numbers in this assay, from the lowest: compound 3; then compounds 4 and 2 (each within the scatter of the next); then compound 1.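

Read as a single change on the shared core, the spiro-fused group in place of piperidin-1-yl gives in this assay a 3.4-fold lower number from compound 1 to compound 4 (0.53 log units; beyond the scatter) and so moves the number by a modest step that lies beyond the scatter. For the compounds shown here, compound 2 and compound 3 carry the same group but differ from compound 1 in several places at once, so this pair is the first to tie a step to this change alone. Nothing measured here accounts for the step.

The compounds shown leave open whether the change gives a similar step on the cores of compound 2 and compound 3, neither of which has a piperidin-1-yl partner. They also leave open how a morpholine at this position would compare with either group.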